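This account rests on a few compounds, and the source may have more. Where it says the series, first, only, none or still open, it means among the compounds named here.

The three measured compounds, each with its number in an assay on isolated protein for inhibition of serine protease 1 (Bos taurus); on this read-out higher numbers stand for weaker inhibition and lower numbers for stronger inhibition:

Compound 1, `CC(=N)N1CCC(Oc2ccc3ncn(Cc4ccc5ccc(C(=N)N)cc5c4)c3c2)CC1`, gives 50 nM.
Compound 2, `CCCc1nc2ccc(OC3CCN(C(C)=N)CC3)cc2n1Cc1ccc2ccc(C(=N)N)cc2c1`, gives 6.8 nM.
Compound 3, `CC(=N)N1CCC(Oc2ccc3nc(CCC(N)=O)n(Cc4ccc5ccc(C(=N)N)cc5c4)c3c2)CC1`, gives 4.4 nM.

Compound 3 has the lowest number of the three, but its distance from compound 2 lies within the scatter, so the two cannot be separated; only compound 1 stands clearly apart, as an 11-fold lower number from compound 1 to compound 3 (1.06 log units; beyond the scatter) shows. Compound 4, `CC(=N)N1CCC(Oc2ccc3nc(CCC(=O)O)n(Cc4ccc5ccc(C(=N)N)cc5c4)c3c2)CC1`, differs from compound 3 in a single atom at the far end of the chain on the shared core: hydroxy in place of amino on a carbonyl carbon. Two kinds of measured step speak to this spot. Putting a chain on the bare core helped in both cases, a 7.4-fold lower number from compound 1 to compound 2 (0.87 log units; beyond the scatter) and an 11-fold lower number from compound 1 to compound 3 (1.06 log units; beyond the scatter). Changing only the end of that chain, however, did little, as a 1.5-fold lower number from compound 2 to compound 3 (0.19 log units; within the scatter) lies within the scatter. The move from amino to hydroxy is once more a change at the chain end alone, so the expectation for this assay is a step of a 1.8-fold higher number from compound 3 to compound 4 (0.26 log units; within the scatter), not beyond the scatter. On that basis compound 4 is estimated at 8 nM, with a likely range from 2 nM to 40 nM.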

Compound 4, inhibition constant: 18 nM
Estimate against measurement, compound 4: 2.3-fold (0.35 log units) below; low and high end bracket the measured number.
By their numbers in this assay, from the lowest: compounds 3 and 2 (each within the scatter of the next); then compound 4; then compound 1.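

Within the data shown here, this position turns out to be sensitive to the end of the chain, which the earlier compounds did not show: in this assay, hydroxy in place of amino on the carbonyl carbon gives (a 4.1-fold higher number from compound 3 to compound 4 (0.61 log units; beyond the scatter)), whereas the earlier change at the chain end, (a 1.5-fold lower number from compound 2 to compound 3 (0.19 log units; within the scatter)), stayed within the scatter. The 2-carboxyethyl chain still improves on the bare core (a 2.8-fold lower number from compound 1 to compound 4 (0.44 log units; beyond the scatter)), so a chain at this spot keeps some benefit with either ending, yet it gives up ground against the plain propyl chain (a 2.6-fold higher number from compound 2 to compound 4 (0.42 log units; beyond the scatter)), so the chain's benefit depends on what ends it. No measurement here explains why the carboxy and carbamoyl ends differ.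

Still open, from the compounds shown here alone, is whether the gap between these two ends holds at other chain lengths, which carbamoylmethyl and carboxymethyl, or a longer chain with the same ends, could test. Going by these compounds, it is also open how other chain ends compare at this position, such as a methyl ester or an amine on the same chain.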